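A Methyl on the Linking Nitrogen of an Inactive Core

This account rests on a few compounds, and the source may have more. Where it says the series, first, only, none or still open, it means among the compounds named here.

Compound 1 `c1cc(N2CCCC2)nc(Nc2ccc(Oc3ncnc4ccsc34)cc2)n1` was tested in a functional assay on A549 cells (Homo sapiens) for inhibition, read by MTT assay, with a stated time of 72 h (on this read-out higher numbers stand for weaker inhibition and lower numbers for stronger inhibition), and returned "not active" (no number reported), so no single number marks where compound 1 stands. Compound 2 `c1cc(N2CCCC2)nc(Nc2ccc(Oc3ncnc4sccc34)cc2)n1`, which shares the core, gives 8100 nM in this assay. Compound 3 `CN(c1ccc(Oc2ncnc3ccsc23)cc1)c1nccc(N2CCCC2)n1` is not yet measured; it differs from compound 1 by methyl in place of hydrogen on a nitrogen on an aromatic ring. Going by the values given here, no measured step of this kind is available, so the size of the move in this assay is only an expectation: a small shift, if any, with weak inhibition remaining the likely outcome. Compound 3 is thus expected to give about 30000 nM, in the range 8000 nM to 100000 nM, with a fair chance of another unnumbered result.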

Compound 3, half-maximal inhibitory concentration: 6510 nM
For compound 3 the middle estimate is 4.6-fold (0.66 log units) above the measured one; the measured number lies below the stated range.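

In this assay compound 1 carries no number, so the step to compound 3 cannot be read. No measured evidence bears on this result. Going by these compounds, whether methyl in place of hydrogen on that nitrogen changes inhibition in this assay remains open.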